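The compounds below may be only part of what the source reports. "The series", "measured", "known", "first", "only" and "open" are said of these compounds alone.

Compound 3 `CC(C)CCn1nc(-c2cccs2)c(O)c(C2=NS(=O)(=O)c3cc(CCC(N)=O)ccc3N2)c1=O` stands at the top of the numbers shown so far. In an in vitro ADME assay on microsomes from liver (Homo sapiens) for metabolic stability, tested at 5 uM (on this read-out lower numbers stand for a shorter-lived compound and higher numbers for a longer-lived compound), compound 3 gives > 1 h, a limit of the assay rather than a read number. Compound 2 `CC(C)CCn1nc(-c2cccs2)c(O)c(C2=NS(=O)(=O)c3cc(OCC(=O)NO)ccc3N2)c1=O` carries a (hydroxycarbamoyl)methoxy group on the aromatic carbon where compound 3 carries its 2-carbamoylethyl group. In this assay compound 2 gives > 1 h, again a limit. Among the measured compounds shown here, the unsubstituted parent, compound 1 `CC(C)CCn1nc(-c2cccs2)c(O)c(C2=NS(=O)(=O)c3ccccc3N2)c1=O`, gives 0.2 h in this assay and is the only compound with a read number. The other two sit at the upper limit (the limit of > 1 h in this assay, at which 2 of the 3 values shown sit).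

Compound 4 `CC(=O)Nc1ccc2c(c1)S(=O)(=O)N=C(c1c(O)c(-c3cccs3)nn(CCC(C)C)c1=O)N2` differs from compound 3 by acetamido in place of 2-carbamoylethyl on an aromatic carbon. Of the measured steps, the one from hydrogen to the 2-carbamoylethyl group, an at least 5.0-fold higher number from compound 1 to compound 3 (0.69 log units; beyond the scatter), bears most directly on this change, and an at least 5.0-fold higher number from compound 1 to compound 2 (0.69 log units; beyond the scatter) shows the same direction for a different substituent on that carbon. The step between the two substituted compounds, a step that the two limits leave unreadable from compound 2 to compound 3, cannot be read.

Both substituents on this carbon carried the compound to the limit, so compound 4, which keeps a substituent there, is expected to lie near the limit too, with a step of a number no higher from compound 3 to compound 4 (the limit leaves the size open) that is expected to be small. Compound 4 is estimated at 1 h in this assay, within a range from 0.4 h to 2.5 h.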

Compound 4, half-life: 0.055 h
Estimate against measurement, compound 4: 18-fold (1.26 log units) above; measured number outside the range, below it.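

The result shows that in this assay a substituent on this aromatic carbon does not by itself give a higher number, since acetamido in place of hydrogen gives a 3.6-fold lower number from compound 1 to compound 4 (0.56 log units; beyond the scatter), opposite in direction to the steps seen with the two earlier substituents. The identity of the group therefore matters a great deal: acetamido in place of 2-carbamoylethyl gives an at least 18-fold lower number from compound 3 to compound 4 (1.25 log units; beyond the scatter), and acetamido in place of (hydroxycarbamoyl)methoxy gives an at least 18-fold lower number from compound 2 to compound 4 (1.25 log units; beyond the scatter), even though acetamido and 2-carbamoylethyl have the same counts of hydrogen-bond donors and acceptors and differ by a single heavy atom. These two large steps start from limits and not from read numbers, so their true size stays open at the upper end: the limit of > 1 h in this assay, at which 2 of the 4 values shown sit.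

The compounds shown leave open where an amine or a carboxylic acid on this aromatic carbon would fall relative to compound 1 and compound 4, and whether a longer chain would behave like acetamido or like 2-carbamoylethyl. From the compounds shown here alone, they also give no measured property that accounts for the fall with acetamido, and how far compound 2 and compound 3 lie beyond their limits remains unknown.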